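This account rests on a few compounds, and the source may have more. Where it says the series, first, only, none or still open, it means among the compounds named here.

Compound 1 `COc1cccc(NC(=S)N/N=C/c2ccc3ccccc3n2)c1` stands alone among the measured compounds in giving an actual number in a functional assay on HL-60 cells (Homo sapiens) for antiproliferative activity, read by sulforhodamine B assay, with a stated time of 72 h; a higher number here means a weaker inhibitor, a lower number a stronger inhibitor: compound 1 gives 71200 nM. Compound 2 `NC(=S)N/N=C/c1nc2ccccc2s1` reaches only a limit in this assay, > 100000 nM. Compound 3 `CN(C)C(=S)N/N=C/c1cc2cccnc2s1` likewise gives only a limit in this assay, > 100000 nM. The picture of the measured compounds is thus set by the limit of > 100000 nM in this assay, at which 2 of the 3 values shown sit, with compound 1 the single numeric point. Compound 4 `Fc1ccc(NC(=S)N/N=C/c2ccc3ccccc3n2)cc1` differs from compound 1 in one place only: 4-fluorophenyl in place of 3-methoxyphenyl on an amide-type nitrogen. Among the compounds with values here, no step between measured compounds bears on this exchange, so the step expected in this assay, a 1.1-fold lower number from compound 1 to compound 4 (0.04 log units; within the scatter), is taken to lie within the usual scatter, in no firm direction. Compound 4 is accordingly estimated at 65000 nM, within a range from 20000 nM to 200000 nM.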

Compound 4, half-maximal inhibitory concentration: 17000 nM
Compound 4: middle estimate off by 3.8-fold (0.58 log units), on the high side; measured number below the stated range.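

In this assay, within the data shown here, the exchange of 3-methoxyphenyl for 4-fluorophenyl on an amide-type nitrogen gives a 4.2-fold lower number from compound 1 to compound 4 (0.62 log units; beyond the scatter), so this position on the shared core responds to the group it carries, which the earlier compounds could not show. Compound 4 adds a second numeric point, while the rest of the set stays unresolved: the limit of > 100000 nM in this assay, at which 2 of the 4 values shown sit.

The compounds shown leave open whether the step belongs to the fluorine gained or the methoxy lost. They also leave open how a plain phenyl or a cyclohexyl group would read at this position.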